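Methoxy for methyl on the aryl of the shared core

The source may report more compounds than this note shows. Statements on the series, on what has been measured and on what is new or still open speak of the compounds shown alone.

In a functional assay on HCT-116 cells (Homo sapiens) for antiproliferative activity, read by MTT assay, with a stated time of 72 h (on this read-out higher numbers stand for weaker inhibition and lower numbers for stronger inhibition), compound 1 `CCCCCc1ccc(-c2cn(C[C@H](O)[C@H]3OC(=O)C(OCc4ccccc4)=C3OCc3ccccc3)nn2)cc1` gives 13800 nM. Compound 2 `Cc1ccc(-c2cn(C[C@H](O)[C@H]3OC(=O)C(OCc4ccccc4)=C3OCc3ccccc3)nn2)cc1` reaches only the limit of this assay, > 100000 nM. That shortening of the chain is an at least 7.2-fold higher number from compound 1 to compound 2 (0.86 log units; beyond the scatter), with compound 2 at the limit of > 100000 nM in this assay, at which 1 of the 2 values shown sits. Compound 3 `COc1ccc(-c2cn(C[C@H](O)[C@H]3OC(=O)C(OCc4ccccc4)=C3OCc3ccccc3)nn2)cc1` carries methoxy in place of methyl on an aromatic carbon. Among the compounds with values here, the one measured step concerns chain length at the same aromatic carbon, so it bears only loosely on this swap, and compound 2 offers no numeric baseline. The expected step is a number no higher from compound 2 to compound 3 (the limit leaves the size open) for compound 3, none beyond the scatter. Compound 3 is estimated at 100000 nM, range 30000 nM to 300000 nM.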

Compound 3, half-maximal inhibitory concentration: > 100000 nM
Compound 3: no number, only a limit; the forecaster's own chance of this, stated with the estimate: 65%; the middle value sits exactly at the limit.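

Compound 3 in this assay gives > 100000 nM as a limit of the assay and not a number, so the step from methyl to methoxy cannot be read. Methoxy in place of pentyl on this aromatic carbon gives an at least 7.2-fold higher number from compound 1 to compound 3 (0.86 log units; beyond the scatter) and leaves pentyl as the only group shown here with a numeric value. Methyl and methoxy now share the same ceiling: the limit of > 100000 nM in this assay, at which 2 of the 3 values shown sit.

As far as these compounds go, whether methyl and methoxy differ at all stays open. Also open, from the compounds shown here alone, is what a propyl chain, an octyl chain or an amine would give on this aromatic carbon.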